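The source may hold more compounds than are shown below. What is called first, only, known or untested is meant among the compounds shown, and "the series" means these compounds.

Compound 1 `CC(=O)Nc1ccn([C@@H]2CO[C@H](CO)O2)c(=O)n1`: 6870 nM
Compound 2 `CCCCCCCCCC(=O)Nc1ccn([C@@H]2CO[C@H](CO)O2)c(=O)n1`: 24 nM

Both values come from a functional assay on A549 cells (Homo sapiens) for cytotoxicity, read by sulforhodamine B assay, with a stated time of 72 h (a higher number here means a weaker inhibitor, a lower number a stronger inhibitor), which measures how strongly each compound holds back the growth of a lung cancer cell line. For the measured compounds named here, compound 2 stands lowest of the two numbers; its only neighbour is compound 1, which gives 6870 nM in this assay, a far higher number. Compound 3 `CCCCCCCCCCCCCCCCCCCCCC(=O)Nc1ccn([C@@H]2CO[C@H](CO)O2)c(=O)n1` differs from compound 2 by a single change: dodecyl in place of hydrogen on a saturated chain carbon, nine bonds along the chain from a carbonyl carbon. Going by the values given here, only one measured step bears on this, the lengthening of the chain on the carbonyl carbon, which gave a 290-fold lower number from compound 1 to compound 2 (2.46 log units; beyond the scatter), a large gain. Among the compounds with values here, whether a further, much longer chain repeats that gain cannot be read from two points; the one step seen points downward, so a modest further fall in this assay is expected for compound 3, within a broad range, giving a 1.6-fold lower number from compound 2 to compound 3 (0.20 log units; within the scatter). Compound 3 is therefore estimated at 15 nM, between 3 nM and 300 nM.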

Compound 3, half-maximal inhibitory concentration: 500 nM
For compound 3 the middle estimate is 33-fold (1.52 log units) below the measured one, outside the stated range (above it).
By their numbers in this assay, from the lowest: compound 2; then compound 3; then compound 1.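

In this assay, lengthening the chain on the carbonyl carbon does not keep lowering the number: dodecyl at this position gives a 21-fold higher number from compound 2 to compound 3 (1.32 log units; beyond the scatter), so the earlier gain reverses. Chain length therefore does not act in one direction here, and the lowest number belongs to the compound with the middle chain, although compound 3 at 500 nM still lies under compound 1 at 6870 nM. Nothing shown here accounts for this reversal.

The compounds shown leave open how sharply the number turns upward as the chain grows past that of compound 2, and whether a chain slightly longer than that one would do better still. They also leave open how a chain ending in an amine or a carboxylic acid would compare.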